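Ethynyl replaces 1-benzofuran-2-yl on the shared core

This account rests on a few compounds, and the source may have more. Where it says the series, first, only, none or still open, it means among the compounds named here.

Measured in a functional assay on CCRF-CEM cells (Homo sapiens), read by MTT assay, with a stated time of 72 h; on this read-out higher numbers stand for weaker inhibition and lower numbers for stronger inhibition:
- compound 1 `COc1ncnc2c1c(-c1ccccc1)cn2[C@@H]1O[C@H](CO)[C@@H](O)[C@H]1O`: > 20000 nM (a limit)
- compound 2 `COc1ncnc2c1c(-c1cc3ccccc3o1)cn2[C@@H]1O[C@H](CO)[C@@H](O)[C@H]1O`: 5370 nM

Compound 1 gives only a limit, > 20000 nM. Within the data shown here, compound 2, at 5370 nM, therefore holds the only actual number so far. Compound 3 `C#Cc1cn([C@@H]2O[C@H](CO)[C@@H](O)[C@H]2O)c2ncnc(OC)c12` differs from it by ethynyl in place of 1-benzofuran-2-yl on an aromatic carbon. Among the measured compounds shown here, the one measured step at this place, an at least 3.7-fold lower number from compound 1 to compound 2 (0.57 log units; beyond the scatter), exchanged one ring group for another, so it bears only loosely on an ethynyl group. It still suggests a modest change in this assay, with the direction uncertain. The expected step is a 2.7-fold lower number from compound 2 to compound 3 (0.43 log units; beyond the scatter). For compound 3 the estimated value is 2000 nM, with an expected range of 200 nM to 20000 nM.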

Compound 3, half-maximal inhibitory concentration: > 20000 nM
Compound 3: no number, only a limit; the forecaster's own chance of this, stated with the estimate: 25%; middle value at least 10-fold (1.00 log units) away from the limit.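

In this assay, ethynyl in place of 1-benzofuran-2-yl gives an at least 3.7-fold higher number from compound 2 to compound 3 (0.57 log units; beyond the scatter), so 1-benzofuran-2-yl is the only group shown at this position that yields an actual number. The step from compound 1 to compound 3 cannot be read, as both values are limits. The results at this position mostly end at one limit: the limit of > 20000 nM in this assay, at which 2 of the 3 values shown sit.

As far as these compounds go, it remains open whether a furan-2-yl group, with the five-membered aromatic ring alone, would also give a number. The same holds for a naphthalen-2-yl group, with two six-membered aromatic rings of carbon only.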